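Changing the amine on the trifluoromethyl compound

The source may report more compounds than this note shows. Statements on the series, on what has been measured and on what is new or still open speak of the compounds shown alone.

Values measured so far in a functional assay on V79 cells (Cricetulus griseus) for cytotoxicity, read by colony formation (on this read-out higher numbers stand for weaker inhibition and lower numbers for stronger inhibition), are these
compound 1 `O=C(O)c1cn(C2CC2)c2c(Cl)c(N3CCNCC3)c(F)cc2c1=O` gives 43 ug/mL
compound 2 `COc1c(N2CCNCC2)c(F)cc2c(=O)c(C(=O)O)cn(C3CC3)c12` gives 82 ug/mL
compound 3 `O=C(O)c1cn(C2CC2)c2c(C(F)(F)F)c(N3CCNCC3)c(F)cc2c1=O` gives 1650 ug/mL

Compound 3 has the highest number of the three. The steps that reach it are both large (a 38-fold higher number from compound 1 to compound 3 (1.58 log units; beyond the scatter) and a 20-fold higher number from compound 2 to compound 3 (1.30 log units; beyond the scatter)), whereas the remaining step stays within the scatter (a 1.9-fold higher number from compound 1 to compound 2 (0.28 log units; within the scatter)).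

Compound 4 `NC1CCCN(c2c(F)cc3c(=O)c(C(=O)O)cn(C4CC4)c3c2C(F)(F)F)C1` keeps the trifluoromethyl group of compound 3 but carries 3-aminopiperidin-1-yl in place of piperazin-1-yl on an aromatic carbon. Among the measured compounds shown here, no measured step covers this change, since compound 1, compound 2 and compound 3 all carry piperazin-1-yl. Those steps show only that one substitution elsewhere on the shared core can move the number widely in this assay here. With compound 3 at the top of this small set (1650 ug/mL), a moderate move towards a lower number is expected, with much uncertainty. The estimated change is a 2.8-fold lower number from compound 3 to compound 4 (0.44 log units; beyond the scatter) in this direction. For compound 4 the expected value is 600 ug/mL, with an estimated range from 120 ug/mL to 2500 ug/mL.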

Compound 4, half-maximal inhibitory concentration: > 500 ug/mL
Compound 4: only a limit was reported (the forecaster's own chance of this, stated with the estimate: 15%); the middle value lies beyond the limit too.
By their numbers in this assay, from the lowest: compounds 1 and 2 (each within the scatter of the next); then compound 3.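

In this assay compound 4 gives > 500 ug/mL, which is a limit and not a number, so the step from compound 3 to compound 4 cannot be read. The compounds shown leave open how far, or in which direction, 3-aminopiperidin-1-yl in place of piperazin-1-yl moves the number.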